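A few compounds are considered here, and "the series" means these few. Any claim that something is new, unique, unknown or untested is made for them only; others in the source may bear on it.

Measured compounds:
- compound 1 `O=C(Nc1ccc(S(=O)(=O)N2CCC(O)CC2)cc1)c1ccc([N+](=O)[O-])o1`: > 25000 nM
- compound 2 `O=C(Nc1ccc(S(=O)(=O)N2CCC(F)CC2)cc1)c1ccc([N+](=O)[O-])o1`: > 25000 nM

In an ADME assay on IMR-90 cells (Homo sapiens) for cytotoxicity, read by CellTiter-Blue, with a stated time of 46 h (a higher number here means that more compound is needed for the effect, a lower number that less compound is needed), compound 1 gives > 25000 nM, which is a limit of the assay rather than a number. Compound 2 gives > 25000 nM, again a limit. The step that the two limits leave unreadable from compound 1 to compound 2 therefore cannot be read in size, because both values sit at the limit of > 25000 nM in this assay, at which 2 of the 2 values shown sit. Compound 2 thus stands at the limit, with no number of its own.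

Compound 3 `O=C(Nc1ccc(S(=O)(=O)C2CCCCC2)cc1)c1ccc([N+](=O)[O-])o1` differs from compound 2 by cyclohexyl in place of 4-fluoropiperidin-1-yl on a sulfonyl sulfur. Going by the values given here, no measured step shows what this change does to cytotoxicity; the only measured step, from compound 1 to compound 2, is unreadable. So no step beyond the scatter is expected, and compound 3 is expected to stay at the limit as well. The estimate for compound 3 is 40000 nM, with a range from 15000 nM to 100000 nM. The expected step is a step that the limit leaves unreadable from compound 2 to compound 3, most likely reported again only as a limit.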

Compound 3, half-maximal effective concentration: > 25000 nM
Compound 3 was reported as a limit; the forecaster's own chance of this, stated with the estimate: 85%; the middle value does not contradict the limit.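

In this assay compound 3 gives > 25000 nM as a limit and not a number. Going by these compounds alone, no step among compound 1, compound 2 and compound 3 can be read in size: the limit of > 25000 nM in this assay, at which 3 of the 3 values shown sit. The compounds shown leave open what concentration, if any, would produce the effect for each of them.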